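Diethylamino for Methoxy: Estimating Compound 4

The compounds below may be only part of what the source reports. "The series", "measured", "known", "first", "only" and "open" are said of these compounds alone.

Compound 1 `COc1ccc(/C=C/c2cc(OC)cc(OC)c2/C=C/C(=O)c2ccc(C)c(C)c2)cc1` gives 1.4 ug/mL in a functional assay on B16-F10 cells (Mus musculus) for antiproliferative activity, read by MTT assay, with a stated time of 48 h; on this read-out higher numbers stand for weaker inhibition and lower numbers for stronger inhibition.
Compound 2 `COc1ccc(/C=C/c2cc(OC)cc(OC)c2/C=C/C(=O)c2ccc(Br)cc2)cc1` gives 6.5 ug/mL.
Compound 3 `COc1ccc(/C=C/c2cc(OC)cc(OC)c2/C=C/C(=O)c2ccc(OC)cc2)cc1` gives 5.8 ug/mL.

Compound 3 stands second highest of the three numbers, close to compound 2 and clearly above compound 1; a 4.1-fold higher number from compound 1 to compound 3 (0.62 log units; beyond the scatter) and a 4.6-fold higher number from compound 1 to compound 2 (0.67 log units; beyond the scatter) are modest steps, while a 1.1-fold lower number from compound 2 to compound 3 (0.05 log units; within the scatter) stays within the scatter. Compound 4 `CCN(CC)c1ccc(C(=O)/C=C/c2c(/C=C/c3ccc(OC)cc3)cc(OC)cc2OC)cc1` differs from compound 3 by diethylamino in place of methoxy on an aromatic carbon. Among the measured compounds shown here, no measured step tests diethylamino itself; the only step at this aromatic carbon, compound 2 to compound 3, shows nothing beyond scatter. The step is therefore expected to be no larger than the scatter, with no direction, so a 1.1-fold lower number from compound 3 to compound 4 (0.02 log units; within the scatter) is the estimate. Compound 4 is expected to give about 5.5 ug/mL, between 1.8 ug/mL and 17 ug/mL.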

Compound 4, half-maximal inhibitory concentration: 8.1 ug/mL
Compound 4: middle estimate off by 1.5-fold (0.17 log units), on the low side; the range from low to high includes it.
By their numbers in this assay, from the lowest: compound 1; then compounds 3, 2 and 4 (each within the scatter of the next).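

Diethylamino has more heavy atoms than methoxy, yet this change at the aromatic carbon leaves the number within the scatter, with a 1.4-fold higher number from compound 3 to compound 4 (0.15 log units; within the scatter) and a 1.2-fold higher number from compound 2 to compound 4 (0.10 log units; within the scatter). Methoxy, bromo and diethylamino therefore cannot be told apart here, while the 3,4-dimethylphenyl group stays separate, with a 5.8-fold higher number from compound 1 to compound 4 (0.76 log units; beyond the scatter) beyond the scatter. No measurement shown here explains these results.

As far as these compounds go, whether a carboxylic acid or a primary amine at this carbon would separate from these three groups remains open. So does whether one methyl alone, rather than both methyls of compound 1, would give its lower number.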